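Series notes: aryl-linked benzothiazole ethers, cytotoxicity step

The source may hold more compounds than are shown below. What is called first, only, known or untested is meant among the compounds shown, and "the series" means these compounds.

Of the compounds shown here, three of the shared core have been measured in a functional assay on COLO 205 cells (Homo sapiens) for cytotoxicity, read by MTT assay, with a stated time of 24 h; a higher number here means a weaker inhibitor, a lower number a stronger inhibitor. Compound 1 `Fc1ccc(-n2cc(COc3ccccc3-c3nc4ccccc4s3)nn2)cc1Cl` gives 14400 nM in this assay. Compound 2 `FC(F)(F)Oc1ccc(-c2cc(COc3ccccc3-c3nc4ccccc4s3)on2)cc1` gives 19900 nM in this assay. Compound 3 `FC(F)(F)C(F)(F)C(F)(F)C(F)(F)C(F)(F)C(F)(F)C(F)(F)C(F)(F)CCn1cc(COc2ccccc2-c2nc3ccccc3s2)nn1` gives 12200 nM in this assay. Among the measured compounds shown here, compound 2 stands among the three numbers with both of its gaps, to compound 1 and to compound 3, inside the usual scatter of repeated measurements, so the three numbers are read as indistinguishable on the present data and no compound can be singled out as more or less potent than the others.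

Compound 4 `Cc1ccc(-c2cc(COc3ccccc3-c3nc4ccccc4s3)on2)cc1` has not been measured in this assay. It differs from compound 2 in one place: methyl in place of trifluoromethoxy on an aromatic carbon. For the measured compounds named here, no pair of measured compounds shows this difference, so the size of the step from compound 2 to compound 4 is not known from the numbers. Since the three measured compounds with quite different outer groups all return numbers within the scatter of one another, no step beyond the scatter is expected here either. The step from compound 2 to compound 4 is expected to be a 1.2-fold lower number from compound 2 to compound 4 (0.07 log units; within the scatter). Compound 4 is estimated at 17000 nM in this assay, with a range from 6000 nM to 50000 nM.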

Compound 4, half-maximal inhibitory concentration: 14200 nM
Compound 4: the middle estimate sits 1.2-fold (0.08 log units) above what was measured; the range from low to high includes it.
By their numbers in this assay, from the lowest: compounds 3, 4, 1 and 2 (each within the scatter of the next).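

Among the compounds shown here, this is the first step that isolates a single place: in this assay, going from 4-(trifluoromethoxy)phenyl to 4-methylphenyl gives a 1.4-fold lower number from compound 2 to compound 4 (0.15 log units; within the scatter). For the compounds shown here, at this position, on an aromatic carbon para to a large group, the five heavy atoms and the hydrogen-bond acceptor of trifluoromethoxy can therefore give way to the single carbon of methyl with no step beyond the scatter, something the earlier compounds, which differ from one another in more than one place, could not show. Nothing available bears on why this exchange leaves the number within the scatter.

As far as these compounds go, whether an amine, a carboxylic acid or a longer chain at this same position would give a step beyond the scatter remains open, since both groups compared here are small, uncharged and without a ring. Also open, from the compounds shown here alone, is whether the exchange of trifluoromethoxy for methyl would read the same on the outer part of compound 1, as this single step speaks only for the pair it joins.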